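Trimming the diene end from compound 3 to compound 4

This account rests on a few compounds, and the source may have more. Where it says the series, first, only, none or still open, it means among the compounds named here.

In a functional assay on the whole organism with Canis familiaris (Canis lupus familiaris) as the target (a lower number here means that less compound is needed, a higher number that more compound is needed for the effect), compound 3 `C/C=C(C)/C=C/[C@](C)(O)C/C=C/[C@H]1[C@H](O)CC(=O)[C@@H]1CC/C=C\CCC(=O)OC` gives 0.000003 mg/kg and holds the lowest of the three numbers, ahead of compound 1 `C=C/C=C/[C@](C)(O)C/C=C/[C@H]1[C@H](O)CC(=O)[C@@H]1CC/C=C\CCC(=O)OC` at 0.000007 mg/kg and compound 2 `C=C/C(C)=C/[C@](C)(O)C/C=C/[C@H]1[C@H](O)CC(=O)[C@@H]1CC/C=C\CCC(=O)OC` at 0.00071 mg/kg in this series.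

Compound 4 `C=C(C)/C=C/[C@](C)(O)C/C=C/[C@H]1[C@H](O)CC(=O)[C@@H]1CC/C=C\CCC(=O)OC` carries 1-methylethenyl in place of 1-methylprop-1-en-1-yl on a double-bonded chain carbon bound to a double-bonded chain carbon.

The closest guide is a 2.3-fold lower number from compound 1 to compound 3 (0.37 log units; beyond the scatter) and it is only modest. Compound 4 is structurally intermediate to that pair, so little movement is expected. The large 100-fold higher number from compound 1 to compound 2 (2.01 log units; beyond the scatter) and a 240-fold lower number from compound 2 to compound 3 (2.37 log units; beyond the scatter) show that changes to this diene can matter, but compound 2 does not carry the 3-methylbuta-1,3-dien-1-yl group of compound 4, and they serve only to widen the range upward.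

The estimated change is a 1.7-fold higher number from compound 3 to compound 4 (0.22 log units; within the scatter) as a slightly higher number, not expected to exceed the scatter.

For compound 4 the expected value is 0.000005 mg/kg with 0.000002 mg/kg to 0.00003 mg/kg as the estimated span.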

Compound 4, dose for half-maximal effect: 0.00002 mg/kg
Compound 4: the middle estimate sits 4.0-fold (0.60 log units) below what was measured; measured number inside the range.
By their numbers in this assay, from the lowest: compound 3; then compound 1; then compound 4; then compound 2.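

In this assay, the change to 1-methylethenyl gives a 6.7-fold higher number from compound 3 to compound 4 (0.82 log units; beyond the scatter), so at this place the result depends on the full 1-methylprop-1-en-1-yl group, not only on its branch. Methyl in place of hydrogen at the same carbon gives a 2.9-fold higher number from compound 1 to compound 4 (0.46 log units; beyond the scatter), so among these compounds, only the larger 1-methylprop-1-en-1-yl group gives a number lower than that of compound 1. The location of the methyl on the diene also counts, as 3-methylbuta-1,3-dien-1-yl in place of 2-methylbuta-1,3-dien-1-yl gives a 36-fold lower number from compound 2 to compound 4 (1.55 log units; beyond the scatter).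

No available data explain these steps. On these data alone, whether a longer chain, such as 1-methylbut-1-en-1-yl, would extend the trend from 1-methylethenyl to 1-methylprop-1-en-1-yl remains open, as does the effect of a phenyl group on this double-bonded chain carbon.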